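Replacing the 4-cyano-2-fluorophenyl group of compound 1

The compounds below may be only part of what the source reports. "The series", "measured", "known", "first", "only" and "open" are said of these compounds alone.

Measured so far:
Compound 1, `CC(C)OC(=O)N1CCC(Oc2ncnc3c2CCN3c2ccc(C#N)cc2F)CC1`: 134%
Compound 2, `CC(C)OC(=O)N1CCC(Oc2ncnc3c2CCN3c2ccc(-c3nccs3)cc2F)CC1`: 74%
Compound 3, `CC(C)SC(=O)N1CCC(Oc2ncnc3c2CCN3c2ccc(S(C)(=O)=O)cc2F)CC1`: 138%

In a functional assay on CHO-K1 cells with Glucose-dependent insulinotropic receptor (Homo sapiens) as the target, read by a luciferase reporter, with a stated time of 5 h (a lower number here means a smaller maximal response, a higher number a larger maximal response), compound 1 gives 134%, the second highest of the three numbers. Compound 3 gives 138%, a value within the usual scatter of compound 1, so the two cannot be ordered. Compound 2 gives 74%, and the step of a number 60 percentage points lower from compound 1 to compound 2 (beyond the scatter) is the only measured step among these compounds.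

Compound 4, `CC(C)OC(=O)N1CCC(Oc2ncnc3c2CCN3c2ccc([S+]([O-])N(C)C)cc2)CC1`, has not yet been measured. It differs from compound 1 as follows: a group of 11 heavy atoms (8 carbon, 1 nitrogen, 1 oxygen, 1 sulfur; one six-membered aromatic ring of carbon only) in place of a group of 9 heavy atoms (7 carbon, 1 nitrogen, 1 fluorine; one six-membered aromatic ring of carbon only), on a nitrogen on an aromatic ring in a ring. Going by the values given here, no measured step describes a change of this kind, since the one measured step replaces only the cyano group, whereas here the fluorine also leaves and a sulfur-bearing group enters. Compound 3, which carries a methylsulfonyl group on its aromatic ring together with a different carbamate, gives a number close to compound 1, so there is no sign that every change at this position lowers the response, but the step to compound 2 shows that a large drop is possible. The expectation for compound 4 is therefore a moderate decrease, a number 22 percentage points lower from compound 1 to compound 4 (beyond the scatter), with wide uncertainty, giving an estimated 112% within a range from 65% to 150%.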

Compound 4, largest response reached (reported as percent of maximum), in percent of the reference or control that the assay uses: 128%
Compound 4: middle estimate off by 16 percentage points, on the low side, and the stated range covers the measured number.
By their numbers in this assay, from the lowest: compound 2; then compounds 4, 1 and 3 (each within the scatter of the next).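

Exchanging the 4-cyano-2-fluorophenyl group for the larger sulfur-bearing group, on a nitrogen on an aromatic ring in a ring, gives in this assay a number 6 percentage points lower from compound 1 to compound 4 (within the scatter). The large drop seen with the 1,3-thiazol-2-yl group of compound 2 therefore does not hold for every replacement here, and the response stays in place even when the nitrile and the fluorine leave together. Nothing available explains why this group and the 1,3-thiazol-2-yl group behave so differently.

The compounds shown leave open what the fluorine does on its own, as no pair differs in that alone. They also leave open whether an amine or a carboxylic acid on the aromatic ring would hold the response at this level.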